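This account rests on a few compounds, and the source may have more. Where it says the series, first, only, none or still open, it means among the compounds named here.

Of the compounds shown here, three sharing one core have been tested in a functional assay on A549 cells (Homo sapiens) for antiproliferative activity, read by MTT assay, with a stated time of 72 h; a lower number here means a stronger inhibitor, a higher number a weaker inhibitor. Compound 1 `COc1cc(N(C)C)c(NC(=O)c2ccnc(Cl)c2)cc1Nc1nccc(-c2cn(C)c3ccccc23)n1` gives 3430 nM, compound 2 `COc1cc(N(C)C)c(NC(=O)c2ccncc2OC)cc1Nc1nccc(-c2cn(C)c3ccccc23)n1` gives 3030 nM, and compound 3 `COc1cc(N(C)C)c(NC(=O)c2ccccn2)cc1Nc1nccc(-c2cn(C)c3ccccc23)n1` gives 8290 nM, the highest number of the three. Compound 4 `COc1cc(N(C)C)c(NC(=O)c2ccnc(Cl)n2)cc1Nc1nccc(-c2cn(C)c3ccccc23)n1` differs from compound 3 in one place: 2-chloropyrimidin-4-yl in place of pyridin-2-yl on a carbonyl carbon. The measured steps that bear on this change both run toward compound 3: a 2.4-fold higher number from compound 1 to compound 3 (0.38 log units; beyond the scatter) and a 2.7-fold higher number from compound 2 to compound 3 (0.44 log units; beyond the scatter). For the measured compounds named here, compound 4 carries, like compound 1, a chlorine on its ring and the same point of attachment to the carbonyl, so a step roughly reversing the one from compound 1 to compound 3 is expected, that is a 2.4-fold lower number from compound 3 to compound 4 (0.37 log units; beyond the scatter). Compound 4 is therefore estimated at 3500 nM, with a range from 1500 nM to 8000 nM.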

Compound 4, half-maximal inhibitory concentration: 2840 nM
Beside the measured number, compound 4's estimate is 1.2-fold (0.09 log units) above it; the measured number falls inside the stated range.
By their numbers in this assay, from the lowest: compounds 4, 2 and 1 (each within the scatter of the next); then compound 3.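

The 2-chloropyrimidin-4-yl group brings a 2.9-fold lower number from compound 3 to compound 4 (0.47 log units; beyond the scatter) but stays level with the other two groups, with a 1.1-fold lower number from compound 2 to compound 4 (0.03 log units; within the scatter) and a 1.2-fold lower number from compound 1 to compound 4 (0.08 log units; within the scatter). Among these four compounds, then, only pyridin-2-yl stands apart at this position, and 2-chloropyrimidin-4-yl cannot be told from 2-chloropyridin-4-yl in this assay. No measurement shown explains why the pyridin-2-yl compound gives the higher number. Going by these compounds, all four groups on the carbonyl carbon are six-membered aromatic rings, so what a cyclohexyl group or a simple methyl group would give remains open.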